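Methyl branching on the chain carbon across two cores

The source may report more compounds than this note shows. Statements on the series, on what has been measured and on what is new or still open speak of the compounds shown alone.

Compound 2 `CC(=O)N(C)CC#CCn1cncc1C` and compound 1 `CC(=O)N(C)C(C)C#CCn1cncc1C` share one core; compound 3 `COC(=O)N(C)CC#CCN1CCCC1` and compound 4 `COC(=O)N(C)C(C)C#CCN1CCCC1` share another, and the difference between the two cores is not broken down here. In a functional assay on the whole organism for antagonist activity, with Mus musculus as the target (on this read-out higher numbers stand for an effect only at larger amounts of compound and lower numbers for an effect already at smaller amounts), compound 1 gives 80 mg/kg. For compound 2 this assay reports only a limit, > 100 mg/kg. For compound 3 this assay likewise reports only a limit, > 10 mg/kg. The change from compound 2 to compound 1 is methyl in place of hydrogen on a saturated chain carbon bound to an amide-type nitrogen and a triple-bonded carbon and gave an at least 1.2-fold lower number from compound 2 to compound 1 (0.09 log units; that floor lies within the scatter); how much further that step might reach cannot be read, since compound 2 sits at the limit of > 100 mg/kg in this assay, at which 1 of the 3 values shown sits. The change from compound 3 to compound 4 is methyl in place of hydrogen on a saturated chain carbon bound to an amide-type nitrogen and a triple-bonded carbon, the same change at the same place. Compound 3 also starts from a bound, (the limit of > 10 mg/kg in this assay, at which 1 of the 3 values shown sits), so the starting point itself is not a number. For the measured compounds named here, on that basis a small step is expected, a step that the limit leaves unreadable from compound 3 to compound 4, about the size of the one seen from compound 2 to compound 1 and therefore within the usual scatter. For compound 4 the estimate in this assay is 20 mg/kg, with an expected range from 8 mg/kg to 100 mg/kg, and a fair chance that compound 4 too is reported only as a limit.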

Compound 4, dose for half-maximal effect: > 100 mg/kg
Compound 4 was reported as a limit (the forecaster's own chance of this, stated with the estimate: 55%); at least 5.0-fold (0.69 log units) between middle value and limit.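

In this assay compound 3 is reported only as a limit, > 10 mg/kg. For the compounds shown here, compound 4 is likewise reported only as a limit, > 100 mg/kg, so no step from compound 3 to compound 4 can be read. The compounds shown leave open whether methyl in place of hydrogen at this chain carbon changes the dose on the core of compound 3 at all, and by how much on either core.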